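This account rests on a few compounds, and the source may have more. Where it says the series, first, only, none or still open, it means among the compounds named here.

Of the compounds shown here, three built on one shared core have been tested in an ADME assay on MT4 cells (Homo sapiens) for cytotoxicity, read by MTT assay; a lower number here means that less compound is tolerated, a higher number that more compound is tolerated. Compound 1 `O=C(CSc1nncnc1-c1ccccc1Cl)Nc1ccccc1`, with phenyl on the amide-type nitrogen, gives 127000 nM. Compound 2 `Cc1ccccc1NC(=O)CSc1nncnc1-c1ccccc1Cl`, with 2-methylphenyl there, gives 142000 nM, and a 1.1-fold higher number from compound 1 to compound 2 (0.05 log units; within the scatter) is a step within the scatter. Compound 3 `O=C(CSc1nncnc1-c1ccccc1Cl)Nc1ccc(Cl)cc1Cl`, with 2,4-dichlorophenyl, gives 51000 nM, the lowest of the three numbers, so it is the least tolerated of this small set.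

Compound 4 `O=C(CSc1nncnc1-c1ccccc1Cl)Nc1cccnc1Cl` has not yet been measured. It has 2-chloropyridin-3-yl in place of 2,4-dichlorophenyl on the amide-type nitrogen (2-chloropyridin-3-yl in place of 2,4-dichlorophenyl on an amide-type nitrogen). Among the measured compounds shown here, no measured step makes this exact swap, so the evidence is indirect. The two steps that bring in 2,4-dichlorophenyl are modest: a 2.5-fold lower number from compound 1 to compound 3 (0.40 log units; beyond the scatter), and a 2.8-fold lower number from compound 2 to compound 3 (0.44 log units; beyond the scatter). Compound 4 gives up that group, so it is expected to recover much of the ground lost in those two steps, though its new ring has not been tested in any other compound here.

The expected change is a modest rise, estimated as a 2.1-fold higher number from compound 3 to compound 4 (0.31 log units; beyond the scatter). For compound 4 the estimated value is 105000 nM, with an expected range from 55000 nM to 190000 nM.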

Compound 4, half-maximal cytotoxic concentration: 167000 nM
Compound 4: the middle estimate sits 1.6-fold (0.20 log units) below what was measured; measured number inside the range.
By their numbers in this assay, from the lowest: compound 3; then compounds 1, 2 and 4 (each within the scatter of the next).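

In this assay, replacing 2,4-dichlorophenyl on the amide-type nitrogen with 2-chloropyridin-3-yl gives a 3.3-fold higher number from compound 3 to compound 4 (0.52 log units; beyond the scatter) and so lifts compound 4 clear of compound 3, which now stands below all three other compounds by more than the scatter. Compound 4 does not separate from the simpler rings, with a 1.3-fold higher number from compound 1 to compound 4 (0.12 log units; within the scatter) and a 1.2-fold higher number from compound 2 to compound 4 (0.07 log units; within the scatter) both being small steps, so a chlorine-bearing ring at this position does not by itself bring the low number seen for compound 3, and a ring containing nitrogen fits here with no loss of tolerance against phenyl or 2-methylphenyl. Nothing measured here explains why 2,4-dichlorophenyl stands apart.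

Compound 3 and compound 4 differ both in the ring nitrogen and in the chlorines they carry, so these compounds cannot show which of those differences goes with the rise, and a group such as 2-chlorophenyl on this nitrogen would be needed to pull them apart. On these data alone, how rings bearing an amine or a carboxylic acid would read at this position also remains open, as does any change to the shared core or to the sulfur-linked chain.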